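The source may hold more compounds than are shown below. What is called first, only, known or untested is meant among the compounds shown, and "the series" means these compounds.

Working notes on the cinnamoyl-triazole series in a functional assay on HepG2 cells (Homo sapiens) for inhibition, read by MTT assay, with a stated time of 48 h, tested at 10 uM; a lower number here means less inhibition of growth, a higher number more inhibition of growth at the concentration tested.

Compound 1 `O=C(/C=C/c1ccc(OCc2cn(Cc3ccccc3)nn2)cc1)c1ccc(Br)cc1` gives 22% in this assay. Compound 2 `COc1ccc(C(=O)/C=C/c2ccc(OCc3cn(Cc4cccc(Br)c4)nn3)cc2)cc1` differs from compound 1 in two places at once; compound 2 gives 27%, and the gap between these two values lies within the usual scatter, so no order can be read from them. Compound 3 `O=C(/C=C/c1ccc(OCc2cn(Cc3ccccc3)nn2)cc1)c1ccc([N+](=O)[O-])cc1` is recorded as "not active" (no number reported) in this assay, with no number reported; on the numbers shown it therefore has no single value to stand on, only the statement that it produced no measurable inhibition at the concentration tested.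

Compound 4 `O=C(/C=C/c1ccc(OCc2cn(Cc3cccc(Br)c3)nn2)cc1)c1ccc([N+](=O)[O-])cc1` is compound 3 with bromo in place of hydrogen on an aromatic carbon, the same change that separates the benzyl group of compound 1 from that of compound 2. Going by the values given here, with no step between measured compounds available for this change, and compound 3 standing at "not active", no step beyond the scatter is expected in this assay for compound 4. Compound 4 is estimated at 10%, in the range 0% to 25%, with a real chance that it is again reported only as not active.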

Compound 4, percent growth inhibition at one concentration: 13%
Estimate against measurement, compound 4: 3 percentage points below; low and high end bracket the measured number.
By their numbers in this assay, from the lowest: compounds 4, 1 and 2 (each within the scatter of the next, the first and the last beyond it).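

With the 3-bromobenzyl group held fixed, nitro in place of methoxy on an aromatic carbon gives a modest step beyond the scatter in this assay (a number 14 percentage points lower from compound 2 to compound 4 (beyond the scatter)). With nitro held fixed, bromo in place of hydrogen on the benzyl group separates compound 3, which has no number, from compound 4 (13%), so a nitro compound can carry a recorded value, although the size of this step cannot be read. Nothing measured here gives a reason for either change.

Still open, going by these compounds, is how an amine or a carboxylic acid in place of nitro on that aromatic carbon would read in this assay. Also open, on these data alone, is whether bromo in place of hydrogen has any readable effect with methoxy on that carbon, or how a longer chain would read in place of the benzyl group.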